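Swapping the Side Group on a Saturated Ring Carbon

A few compounds are considered here, and "the series" means these few. Any claim that something is new, unique, unknown or untested is made for them only; others in the source may bear on it.

compound 1: `C[C@@H](NCC1CCN(CCCc2c[nH]c3ccc(-n4cnnc4)cc23)CC1)c1ccccc1`, 1.4 nM
compound 2: `OC[C@H](NC1CCN(CCCc2c[nH]c3ccc(-n4ccnc4)cc23)CC1)c1ccccc1`, 0.7 nM

Of the compounds shown here, two with a shared core have been measured. In an assay on CHO cells for displacement of a labelled ligand from 5-hydroxytryptamine receptor 1D (Homo sapiens) (a higher number here means a weaker inhibitor, a lower number a stronger inhibitor), compound 1 gives 1.4 nM, and compound 2 gives 0.7 nM. These two values lie within the usual scatter of each other, so neither compound can be called the stronger binder on this evidence. Compound 3 `c1cc(CNC2CCN(CCCc3c[nH]c4ccc(-n5cnnc5)cc34)CC2)co1` has not yet been measured. It differs from compound 1 by ((furan-3-yl)methyl)amino in place of ((1-phenylethyl)amino)methyl on a saturated ring carbon. For the measured compounds named here, no measured pair shows a change of this kind, so the step it brings is uncertain; a modest weakening is expected, amounting to a 3.6-fold higher number from compound 1 to compound 3 (0.55 log units; beyond the scatter). Compound 3 is therefore estimated at 5 nM, within a range of 1.5 nM to 20 nM.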

Compound 3, half-maximal inhibitory concentration: 4.5 nM
The estimate for compound 3 lay 1.1-fold (0.05 log units) above the measured number; measured number inside the range.
By their numbers in this assay, from the lowest: compounds 2 and 1 (each within the scatter of the next); then compound 3.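

For the compounds shown here, putting ((furan-3-yl)methyl)amino in place of ((1-phenylethyl)amino)methyl on this saturated ring carbon gives, in this assay, a 3.2-fold higher number from compound 1 to compound 3 (0.51 log units; beyond the scatter), the first step at this position that can be read beyond the scatter. The change is modest: with the smaller group and no defined stereocentre in it, compound 3 still gives 4.5 nM. Nothing measured here offers a reason for the weakening.

Going by these compounds, the aromatic ring and the chain joining it to the ring carbon change together, so which of them matters stays open. A benzylamino group on this carbon would help separate the two.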